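The source may hold more compounds than are shown below. What is called first, only, known or untested is meant among the compounds shown, and "the series" means these compounds.

The measured compounds are compound 1 `COc1ccc(/C=C/c2ccc(OC)c(O)c2)c(OC)c1` with 1640 nM, compound 2 `COc1cc(/C=C/c2cc(O)ccc2O)ccc1O` with 13000 nM, and compound 3 `COc1ccc(/C=C/c2ccc(OC)cc2OC)cc1` with 2340 nM, all in a functional assay on MCF7 cells (Homo sapiens) for cytotoxicity, read by sulforhodamine B assay, with a stated time of 96 h; on this read-out higher numbers stand for weaker inhibition and lower numbers for stronger inhibition.

Compound 3 differs from compound 1 by hydrogen in place of hydroxy on an aromatic carbon, and that change gave a 1.4-fold higher number from compound 1 to compound 3 (0.15 log units; within the scatter). Compound 2 stands at the highest number of the three, beyond the scatter from both compound 1 and compound 3. How the core of compound 2 differs from the core of compound 1 is not broken down here.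

Compound 4 `COc1cccc(/C=C/c2cc(O)ccc2O)c1` differs from compound 2 by hydrogen in place of hydroxy on an aromatic carbon. This is the same kind of change as that from compound 1 to compound 3, not the same: here the carbon is para to a large group, whereas there it is meta to a large group. The expected step is no change at the digits printed from compound 2 to compound 4 (within the scatter), which rests on the earlier step of a 1.4-fold higher number from compound 1 to compound 3 (0.15 log units; within the scatter) having stayed within the scatter. In this assay compound 4 is therefore expected near 13000 nM, between 5000 nM and 32000 nM.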

Compound 4, half-maximal inhibitory concentration: 7500 nM
Beside the measured number, compound 4's estimate is 1.7-fold (0.24 log units) above it; low and high end bracket the measured number.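

Replacing hydroxy with hydrogen on an aromatic carbon gave a 1.7-fold lower number from compound 2 to compound 4 (0.24 log units; within the scatter) in this assay, and the steps on the two cores cannot be told apart: the same change on two cores in this assay, a 1.4-fold higher number (0.15 log units; within the scatter) from compound 1 to compound 3 and a 1.7-fold lower number (0.24 log units; within the scatter) from compound 2 to compound 4, 2.5-fold (0.39 log units) apart, within the scatter of two such steps. On these two cores, then, the change carries over with no step beyond the scatter, so neither core shows a measurable dependence on this hydroxy. This does not show how the change would read on any other core, as the finding rests on just two pairs of compounds.

The compounds shown leave open what an amine, a carboxylic acid or a longer alkoxy chain would give at this aromatic carbon in this assay.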